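The source may report more compounds than this note shows. Statements on the series, on what has been measured and on what is new or still open speak of the compounds shown alone.

Compound 1 `O=C1CN(C2CCCC2)c2nc(Nc3ccc(N4CCCCC4)cn3)ncc2N1` gives, in a functional assay on HCT-116 cells (Homo sapiens) for inhibition, read by MTT assay, with a stated time of 48 h (on this read-out lower numbers stand for stronger inhibition and higher numbers for weaker inhibition), only the assay limit > 30000 nM. Compound 2 `CC1CCN(c2ccc(Nc3ncc4c(n3)N(C3CCCC3)CC(=O)N4)nc2)CC1` also stops at the limit, > 30000 nM. Compound 3 `O=C1CN(C2CCCC2)c2nc(Nc3ccc(N4CCNCC4)cn3)ncc2N1` likewise stops at the limit, > 30000 nM. The three steps among them, a step that the two limits leave unreadable from compound 1 to compound 2, a step that the two limits leave unreadable from compound 1 to compound 3 and a step that the two limits leave unreadable from compound 2 to compound 3, cannot be sized, since every value sits at the limit of > 30000 nM in this assay, at which 3 of the 3 values shown sit.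

Compound 4 `CN1C(=O)CN(C2CCCC2)c2nc(Nc3ccc(N4CCCCC4)cn3)ncc21` differs from compound 1 by methyl in place of hydrogen on an amide-type nitrogen in a ring. Within the data shown here, the measured steps all concern the group on the aromatic carbon and none touches the amide-type nitrogen, so no measured step bears on this change. The expectation therefore rests on compound 1 alone, which gives a limit, > 30000 nM. With nothing measured to move it, the step of a number no higher from compound 1 to compound 4 (the limit leaves the size open) is expected to be none beyond the scatter. Compound 4 is estimated at 30000 nM, range 10000 nM to 100000 nM, most likely reported once more as a limit.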

Compound 4, half-maximal inhibitory concentration: 3890 nM
Estimate against measurement, compound 4: 7.7-fold (0.89 log units) above; the whole stated range lies above it.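

In this assay, the amide-type nitrogen in a ring is the only place shown where a single change gives a readable result: methyl in place of hydrogen there gives an at least 7.7-fold lower number from compound 1 to compound 4 (0.88 log units; beyond the scatter). The steps on the group on the aromatic carbon cannot be read, so they gave no sign that any change could bring a value off the limit; this step shows that such a change exists with the piperidin-1-yl group and the cyclopentyl group held constant. The size of the step remains a minimum, because compound 1 has no exact number of its own: the limit of > 30000 nM in this assay, at which 3 of the 4 values shown sit.

Going by these compounds, whether an ethyl group or a longer chain on this nitrogen would go further or fall back remains open. Also open, on these data alone, is whether the same methyl would bring compound 2 or compound 3 off the limit.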